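Methoxy addition on the pyridinyl arm of the thienopyridine series

The source may report more compounds than this note shows. Statements on the series, on what has been measured and on what is new or still open speak of the compounds shown alone.

Measured so far:
compound 1 `COC(=O)c1sc2cc(-c3cccs3)cnc2c1N` — 26900 nM
compound 2 `COC(=O)c1sc2cc(-c3cccnc3)cnc2c1N` — > 112000 nM

In a functional assay on MCF7 cells (Homo sapiens) for inhibition, read by sulforhodamine B assay, with a stated time of 48 h (on this read-out higher numbers stand for weaker inhibition of growth and lower numbers for stronger inhibition of growth), compound 1 gives 26900 nM. Compound 2 reaches only the limit of this assay, > 112000 nM, so no number stands for it (the limit of > 112000 nM in this assay, at which 1 of the 2 values shown sits). Among the measured compounds shown here, the change an at least 4.1-fold higher number from compound 1 to compound 2 (0.61 log units; beyond the scatter) is the only measured step, and it does not touch the position now altered. Compound 3 `COC(=O)c1sc2cc(-c3ccc(OC)nc3)cnc2c1N` carries methoxy in place of hydrogen on an aromatic carbon. For the measured compounds named here, with no step bearing on this change, no shift beyond the scatter is expected; the implied step that the limit leaves unreadable from compound 2 to compound 3 is an estimate only. Compound 3 is therefore expected near 150000 nM, within 50000 nM to 450000 nM, most likely again a limit.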

Compound 3, concentration for 50% growth inhibition: > 37500 nM
Compound 3: a limit, no number; the forecaster's own chance of this, stated with the estimate: 70%; the middle value is on the limit's open side.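

Compound 2 is a limit, at > 112000 nM. Among the compounds shown here, compound 3 is also a limit, at > 37500 nM, so no step from compound 2 to compound 3 can be read. On these data alone, whether methoxy in place of hydrogen on an aromatic carbon changes growth inhibition at all stays open.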